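Aryl urea pyrazoles: demethylation step toward compound 4

The source may report more compounds than this note shows. Statements on the series, on what has been measured and on what is new or still open speak of the compounds shown alone.

The series shares the core of compound 1 `O=C(Nc1cccc(-n2cc(-c3ccncc3)c(-c3ccc(Cl)c(O)c3)n2)c1)Nc1cccc(C(F)(F)F)c1` and varies the aryl group on the urea. In a functional assay on HOP-92 cells (Homo sapiens) for inhibition, read by sulforhodamine B assay, with a stated time of 48 h (on this read-out higher numbers stand for lower toxicity in this test and lower numbers for higher toxicity in this test), compound 1 reaches only the limit of the test, > 32500 nM. Compound 2 `O=C(Nc1cccc(-n2cc(-c3ccncc3)c(-c3ccc(Cl)c(O)c3)n2)c1)Nc1ccc(Cl)c(Cl)c1` carries 3,4-dichlorophenyl in place of 3-(trifluoromethyl)phenyl on an amide-type nitrogen. In this assay compound 2 likewise gives only a limit, > 32500 nM. The step that the two limits leave unreadable from compound 1 to compound 2 is thus unreadable. Compound 3 `COc1cc(-c2nn(-c3cccc(NC(=O)Nc4ccc(Cl)c(C(F)(F)F)c4)c3)cc2-c2ccncc2)ccc1Cl` also sits in this assay at a limit, > 32500 nM. Going by the values given here, all values so far share one feature, (the limit of > 32500 nM in this assay, at which 3 of the 3 values shown sit), so no order among the three can be read. Compound 4 `O=C(Nc1cccc(-n2cc(-c3ccncc3)c(-c3ccc(Cl)c(O)c3)n2)c1)Nc1ccc(Cl)c(C(F)(F)F)c1` differs from compound 3 in one place: hydrogen in place of methyl on an oxygen on an aromatic ring, that is methoxy to hydroxy, 4-chloro-3-methoxyphenyl to 4-chloro-3-hydroxyphenyl. Among the compounds with values here, no measured step covers this change, and the only measured step is itself unreadable. The step that the limit leaves unreadable from compound 3 to compound 4 is expected to be nothing readable, a limit again. The estimate for compound 4 is 45000 nM, within 20000 nM to 120000 nM.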

Compound 4, concentration lethal to 50% of the cells: 13500 nM
Beside the measured number, compound 4's estimate is 3.3-fold (0.52 log units) above it; measured number below the stated range.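

Methoxy to hydroxy on the aromatic ring gives the first readable step of the series in this assay, an at least 2.4-fold lower number from compound 3 to compound 4 (0.38 log units; beyond the scatter), so this position bears on the read-out, in the direction of higher toxicity in this test. The hydroxy group does not act alone, since the aryl group on the urea also counts: trifluoromethyl in place of chloro gives an at least 2.4-fold lower number from compound 2 to compound 4 (0.38 log units; beyond the scatter), and chloro in place of hydrogen gives an at least 2.4-fold lower number from compound 1 to compound 4 (0.38 log units; beyond the scatter). Only compound 4 stands off the limit, so all three steps give a minimum size only: the limit of > 32500 nM in this assay, at which 3 of the 4 values shown sit.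

From the compounds shown here alone, the true distance of compound 1, compound 2 and compound 3 from compound 4 stays open, and the step between compound 1 and compound 2 cannot be read. Also open, going by these compounds, is whether an amine or a carboxylic acid in place of the hydroxy group would hold this lower number.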